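The source may hold more compounds than are shown below. What is called first, only, known or untested is meant among the compounds shown, and "the series" means these compounds.

Compound 1 `CC1(c2ccc(Br)cc2)CC(S(=O)(=O)c2ccc(F)cc2)=C(c2ccc(/C(N)=N\O)cc2)O1` has the lower of the two numbers in an ADME assay on HepG2 cells (Homo sapiens) for cytotoxicity, read by MTT assay, with a stated time of 72 h (on this read-out lower numbers stand for higher toxicity in this test and higher numbers for lower toxicity in this test), giving 19200 nM; compound 2 `CC1(Cc2ccccc2)CC(S(=O)(=O)c2cccc(F)c2)=C(c2ccc(/C(N)=N\O)cc2)O1` gives 59600 nM in this assay, a gap beyond the usual scatter. Compound 3 `CC1(c2ccc(-c3ccncc3)cc2)CC(S(=O)(=O)c2ccc(F)cc2)=C(c2ccc(/C(N)=N\O)cc2)O1` has not yet been measured. It differs from compound 1 in one place: pyridin-4-yl in place of bromo on an aromatic carbon. Going by the values given here, no measured pair shows this kind of change, so there is no direct guide to its effect. The step of a 1.3-fold higher number from compound 1 to compound 3 (0.11 log units; within the scatter) is expected to be small, if anything toward lower toxicity. The estimate for compound 3 in this assay is 25000 nM, with a range from 8000 nM to 70000 nM.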

Compound 3, half-maximal cytotoxic concentration: 30300 nM
Compound 3: middle estimate off by 1.2-fold (0.08 log units), on the low side, within the range that was stated.
By their numbers in this assay, from the lowest: compounds 1, 3 and 2 (each within the scatter of the next, the first and the last beyond it).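

In this assay, going by these compounds alone, the swap of bromo for pyridin-4-yl on this aromatic carbon gives a 1.6-fold higher number from compound 1 to compound 3 (0.20 log units; within the scatter) and so shows that this position can carry a whole extra aromatic ring with no shift beyond the usual scatter, something the earlier compounds could not show. No supporting measurement here explains this result. Still open, from the compounds shown here alone, is how an amine, a carboxylic acid or a longer chain in this same place would read, and whether a plain phenyl ring without the ring nitrogen would read the same.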